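The compounds below may be only part of what the source reports. "The series", "measured", "known", "first", "only" and "open" are said of these compounds alone.

In a functional assay on U-251 cells (Homo sapiens) for inhibition, read by MTT assay, with a stated time of 2 days (on this read-out higher numbers stand for weaker inhibition of growth and lower numbers for stronger inhibition of growth), compound 1 `Nc1ccccc1NC(=O)CCCNCC(=O)Nc1ccc(Cl)cc1` gives 11400 nM and compound 2 `Nc1ccccc1NC(=O)CCCNCC(=O)Nc1ccc(Br)cc1` gives 10400 nM, so compound 2 stands level with compound 1 within the scatter. Compound 3 `Nc1ccccc1NC(=O)CCCNCC(=O)Nc1cccc([N+](=O)[O-])c1` follows from compound 2 by 3-nitrophenyl in place of 4-bromophenyl on an amide-type nitrogen. Among the compounds with values here, only one measured step bears on this change, a 1.1-fold lower number from compound 1 to compound 2 (0.04 log units; within the scatter), a swap of bromo for chloro on an aromatic carbon that stays within the scatter. Within the data shown here, no measured compound carries the 3-nitrophenyl group, so that step is a weak guide and gives no direction. No step beyond the scatter is therefore expected in this assay, though the range has to stay wide. The estimated step is a 1.0-fold lower number from compound 2 to compound 3 (0.02 log units; within the scatter). Compound 3 is expected at 10000 nM, with an estimated range of 4000 nM to 25000 nM.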

Compound 3, concentration for 50% growth inhibition: 15000 nM
Compound 3: middle estimate off by 1.5-fold (0.18 log units), on the low side, and the stated range covers the measured number.
By their numbers in this assay, from the lowest: compounds 2, 1 and 3 (each within the scatter of the next).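

In this assay, 3-nitrophenyl in place of 4-bromophenyl on the amide-type nitrogen gives a 1.4-fold higher number from compound 2 to compound 3 (0.16 log units; within the scatter) and 3-nitrophenyl in place of 4-chlorophenyl gives a 1.3-fold higher number from compound 1 to compound 3 (0.12 log units; within the scatter) for the same position. Within the data shown here, the position therefore tolerates more than a swap of one halogen for another: a group with 9 heavy atoms and 2 hydrogen-bond acceptors replaces one with 7 heavy atoms and 0 acceptors, and no step leaves the scatter. No measurement is available to explain these numbers.

Still open, from the compounds shown here alone, is whether 4-nitrophenyl would separate the identity of the group from its place on the ring. Also open, going by these compounds, is whether an aminophenyl or carboxyphenyl group here, or a longer chain in the core, would give a step beyond the scatter.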